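A few compounds are considered here, and "the series" means these few. Any claim that something is new, unique, unknown or untested is made for them only; others in the source may bear on it.

Measured compounds:
compound 1 `O=C(Nc1cccc(-c2oc3cc(-c4ccc(F)cc4)ccc3c(=O)c2O)c1)c1ccc(F)cc1` gives 5350 nM in a functional assay on HeLa cells (Homo sapiens) for antiproliferative activity, read by CCK-8 assay, with a stated time of 72 h; a lower number here means a stronger inhibitor, a higher number a weaker inhibitor
compound 2 `Cc1cc(C(=O)Nc2cccc(-c3oc4cc(-c5ccc(F)cc5)ccc4c(=O)c3O)c2)ccc1F` gives 18900 nM in this assay

Of the two numbers recorded, compound 2 stands at the higher end: the step of a 3.5-fold higher number from compound 1 to compound 2 (0.55 log units; beyond the scatter) separates it from compound 1, and the two compounds differ only on the aryl ring of the benzamide. Compound 3 `COc1ccc(C(=O)Nc2cccc(-c3oc4cc(-c5ccc(F)cc5)ccc4c(=O)c3O)c2)c(F)c1` has not yet been measured. Its change from compound 2 is 2-fluoro-4-methoxyphenyl in place of 4-fluoro-3-methylphenyl on a carbonyl carbon, so the methyl of compound 2 is gone and the ring now carries a fluorine and a methoxy group in new positions.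

Within the data shown here, the one measured step that bears on this ring, from compound 1 to compound 2, shows that a single substituent change there is enough to move the number beyond the scatter, but it does not tell the direction for a ring carrying a methoxy group, which no measured compound has. Compound 3 is therefore expected to land between the two recorded values, nearer compound 1 than compound 2, an estimated step of a 2.1-fold lower number from compound 2 to compound 3 (0.32 log units; beyond the scatter), with wide uncertainty. The estimate for compound 3 is 9000 nM, within a range from 3000 nM to 30000 nM.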

Compound 3, half-maximal inhibitory concentration: 16100 nM
The estimate for compound 3 lay 1.8-fold (0.25 log units) below the measured number; low and high end bracket the measured number.
By their numbers in this assay, from the lowest: compound 1; then compounds 3 and 2 (each within the scatter of the next).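

In this assay, exchanging 4-fluoro-3-methylphenyl for 2-fluoro-4-methoxyphenyl on the carbonyl carbon gives a 1.2-fold lower number from compound 2 to compound 3 (0.07 log units; within the scatter) and so leaves the number unmoved, even though the methyl is gone and a methoxy group has entered the ring. Set against the 4-fluorophenyl ring, the same 2-fluoro-4-methoxyphenyl ring gives a 3.0-fold higher number from compound 1 to compound 3 (0.48 log units; beyond the scatter) as its step, which leaves compound 1 at 5350 nM with the lowest number of the three and shows that two differently substituted rings both stand apart from it in the same direction. No evidence at hand accounts for these numbers.

The compounds shown do not separate the fluorine from the methoxy group in compound 3, so it stays open what a ring carrying only one of the two would give. They also leave open whether an amine, a carboxylic acid or a longer chain such as ethoxy on this ring would bring the number under that of compound 1, or whether changes elsewhere on the shared core would matter more.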